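Pyridin-4-yl in place of 4-hydroxyphenyl on the core

This account rests on a few compounds, and the source may have more. Where it says the series, first, only, none or still open, it means among the compounds named here.

Three compounds on the shared core have been run in a functional assay on MCF7 cells (Homo sapiens) for antiproliferative activity, read by MTT assay, with a stated time of 24 h; a lower number here means a stronger inhibitor, a higher number a weaker inhibitor. Compound 1 `COc1ccc(-c2noc(-c3cccnc3)n2)cc1OC1CCCC1` carries pyridin-3-yl; in this assay it gives > 1000000 nM, which is a limit of the assay rather than a number. Compound 2 `COc1ccc(-c2noc(-c3ccc(F)cc3)n2)cc1OC1CCCC1` carries 4-fluorophenyl and gives 3880 nM. Compound 3 `COc1ccc(-c2noc(-c3ccc(O)cc3)n2)cc1OC1CCCC1` carries 4-hydroxyphenyl and gives 390 nM, the lowest of the two numbers; compound 2 is nearest, a 9.9-fold lower number from compound 2 to compound 3 (1.00 log units; beyond the scatter) apart. Against the limit of compound 1 the steps are large: an at least 250-fold lower number from compound 1 to compound 2 (2.41 log units; beyond the scatter) and an at least 2500-fold lower number from compound 1 to compound 3 (3.40 log units; beyond the scatter).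

Compound 4 `COc1ccc(-c2noc(-c3ccncc3)n2)cc1OC1CCCC1` is not yet measured. It differs from compound 3 as follows: pyridin-4-yl in place of 4-hydroxyphenyl on an aromatic carbon. Among the measured compounds shown here, the nearest measured step is the one from compound 1 to compound 3, which exchanges a pyridyl ring for 4-hydroxyphenyl; the present change runs the other way, to a pyridyl ring again, and the hydroxy donor is lost, as in compound 2. A large step toward a higher number is therefore expected, a 100-fold higher number from compound 3 to compound 4 (2.01 log units; beyond the scatter), with a real chance of another limit. For compound 4 the expected value is 40000 nM, within 3000 nM to 1000000 nM.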

Compound 4, half-maximal inhibitory concentration: > 1000000 nM
Compound 4 ended at the assay's limit; the forecaster's own chance of this, stated with the estimate: 30%; at least 25-fold (1.39 log units) between middle value and limit.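

Pyridin-4-yl at this position gives an at least 2500-fold higher number from compound 3 to compound 4 (3.40 log units; beyond the scatter), and against the fluoro analogue it gives an at least 250-fold higher number from compound 2 to compound 4 (2.41 log units; beyond the scatter). Moving the ring nitrogen from the pyridin-3-yl of compound 1 to the pyridin-4-yl of compound 4 therefore brings back no readable number, so among the four compounds shown, only the substituted phenyl rings of compound 2 and compound 3 give one. The step between compound 1 and compound 4 cannot be read, because both sit at the same limit: the limit of > 1000000 nM in this assay, at which 2 of the 4 values shown sit.

No order of the two pyridyl compounds can be given from these limits. Going by these compounds, whether a readable number returns with 4-aminophenyl, 4-carboxyphenyl or 4-methoxyphenyl on this carbon, or with a hydroxy group on the pyridine ring, stays open.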